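Removing Two Chlorines from an Anilino Thiazole Chalcone

A few compounds are considered here, and "the series" means these few. Any claim that something is new, unique, unknown or untested is made for them only; others in the source may bear on it.

Among the measured compounds shown here, compound 2 `Cc1nc(Nc2ccc(Cl)c(Cl)c2)sc1C(=O)/C=C/c1ccccc1` is the one member of this small set for which a functional assay on PC-3 cells (Homo sapiens) for cytotoxicity, read by MTT assay (a lower number here means a stronger inhibitor, a higher number a weaker inhibitor), returns a number rather than a limit: in this assay compound 2 gives 7990 nM. Compound 1 `Cc1nc(Nc2ccccc2)sc1C(=O)/C=C/c1ccc(Cl)cc1` reaches only the limit of this assay, recorded as > 25000 nM. Compound 3 `COc1cc(/C=C/C(=O)c2sc(Nc3cccc(Cl)c3)nc2C)cc(OC)c1OC` likewise stops at the limit, with > 25000 nM in this assay. Compound 2 therefore stands alone with a measured potency, the other two values being limits (the limit of > 25000 nM in this assay, at which 2 of the 3 values shown sit).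

Compound 4 `Cc1nc(Nc2ccccc2)sc1C(=O)/C=C/c1ccccc1` has not yet been measured. It differs from compound 2 in a single place: phenyl in place of 3,4-dichlorophenyl on a nitrogen on an aromatic ring. Among the three compounds already tested, the sole number belongs to the one that carries the 3,4-dichlorophenyl, while compound 1 and compound 3 sit at the limit of this assay. For the measured compounds named here, with no measured pair isolating this change, the direction can only be guessed from that picture. The step from compound 2 to compound 4 is expected to be a weakening of roughly a 2.5-fold higher number from compound 2 to compound 4 (0.40 log units; beyond the scatter), beyond the usual scatter. Compound 4 is estimated to give about 20000 nM in this assay, with a plausible range from 8000 nM to 60000 nM, and a fair chance that only a limit is reported.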

Compound 4, half-maximal inhibitory concentration: > 25000 nM
Compound 4 was reported as a limit; the forecaster's own chance of this, stated with the estimate: 50%; at least 1.2-fold (0.09 log units) between middle value and limit.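

The change of phenyl in place of 3,4-dichlorophenyl on a nitrogen on an aromatic ring now has a matched pair behind it, and in this assay it gives an at least 3.1-fold higher number from compound 2 to compound 4 (0.49 log units; beyond the scatter). From the compounds shown here alone, with only this place altered, the two chlorines are what separates a measured value from the limit in this pair, but the step is a lower bound and its full size remains unknown. The step from compound 1 to compound 4 cannot be read, since both values are limits, and the set now gathers at that limit: the limit of > 25000 nM in this assay, at which 3 of the 4 values shown sit.

The compounds shown leave open whether one chlorine alone would retain a measurable value at this place, or whether both are needed, and whether another group on the phenyl, such as methoxy, trifluoromethyl or a dimethylamino group, could take their place. They also leave open whether 3,4-dichlorophenyl on the nitrogen would bring compound 1 or compound 3, each now at the limit, to a measurable value.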